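Aryl-for-ester swap on a triazole: cytotoxicity outlook

This account rests on a few compounds, and the source may have more. Where it says the series, first, only, none or still open, it means among the compounds named here.

Measured so far:
compound 1 `COc1nc2ccc(Br)cc2cc1C(c1ccccc1)n1cc(-c2ccccc2)nn1`: 8.25%
compound 2 `CCOC(=O)c1cn(C(c2ccccc2)c2cc3cc(Br)ccc3nc2OC)nn1`: 2%
compound 3 `COc1nc2ccc(Br)cc2cc1C(c1ccccc1)n1cc(-c2ccc(OC(F)(F)F)cc2)nn1`: 5.8%

Of the compounds shown here, three sharing one core have been tested in an ADME assay on HEK293 cells (Homo sapiens) for cytotoxicity, read by sulforhodamine B assay, with a stated time of 48 h, tested at 10 uM; on this read-out higher numbers stand for more inhibition at the one concentration tested (going by the name of the read-out) and lower numbers for less inhibition. Compound 2 stands at the low end of the three numbers, but its nearest neighbour compound 3 is a number 3.8 percentage points higher from compound 2 to compound 3 (within the scatter), and compound 1 sits a number 6.3 percentage points lower from compound 1 to compound 2 (within the scatter), so all three are within the scatter of one another.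

The next compound, compound 4 `COc1nc2ccc(Br)cc2cc1C(c1ccccc1)n1cc(-c2ccccc2C(F)(F)F)nn1`, differs from compound 2 in one place: 2-(trifluoromethyl)phenyl in place of ethoxycarbonyl on an aromatic carbon.

Going by the values given here, two measured steps bear on this change. From compound 1 to compound 2 the phenyl group on that aromatic carbon was replaced by ethoxycarbonyl, and this assay moved a number 6.3 percentage points lower from compound 1 to compound 2 (within the scatter). From compound 2 to compound 3 the reverse kind of change, an aryl group in place of ethoxycarbonyl, gave a number 3.8 percentage points higher from compound 2 to compound 3 (within the scatter). Neither step left the scatter, and nothing measured here separates one aryl substituent from another.

The step from compound 2 to compound 4 is therefore expected to be a number 4 percentage points higher from compound 2 to compound 4 (within the scatter), which is no step beyond the scatter. Compound 4 is expected to give 6%, with a range from 0% to 14%.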

Compound 4, a percentage reported as inhibition, at one concentration (the size of the read-out at that concentration, not a potency): 14.3%
Compound 4: middle estimate off by 8.3 percentage points, on the low side, outside the stated range (above it).
By their numbers in this assay, from the lowest: compounds 2, 3, 1 and 4 (each within the scatter of the next, the first and the last beyond it).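

In this assay, going by these compounds alone, the change from ethoxycarbonyl to 2-(trifluoromethyl)phenyl on this aromatic carbon of the five-membered ring gives a number 12.3 percentage points higher from compound 2 to compound 4 (beyond the scatter) and is the first step to leave the scatter, so the group at this position can move the read-out, if only modestly. The other two new steps stay inside the scatter, a number 8.5 percentage points higher from compound 3 to compound 4 (within the scatter) and a number 6.1 percentage points higher from compound 1 to compound 4 (within the scatter), so compound 4 cannot be told apart from the other two aryl compounds, and compounds 1 and 3 go against any rule that an aryl group here always lifts the number above that of the ester. No measured information on these compounds accounts for the step from the ester to this aryl group.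

As far as these compounds go, it remains open whether a group without a ring on this carbon, such as an amine, a carboxylic acid or a longer alkyl chain, would give a number near that of compound 2 or that of compound 4. From the compounds shown here alone, it is also open whether trifluoromethyl placed elsewhere on the phenyl ring, or a chlorine in its place, would produce a clear step from the ester.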